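The compounds below may be only part of what the source reports. "The series", "measured", "known", "first", "only" and "open" are said of these compounds alone.

Compounds measured in a functional assay on A549 cells (Homo sapiens) for inhibition, read by MTT assay, with a stated time of 72 h, tested at 10 uM; on this read-out higher numbers stand for more inhibition at the one concentration tested (going by the name of the read-out) and lower numbers for less inhibition:
- compound 1, `CCOC(=O)C1=C(Nc2ccccc2)S/C(=C\c2ccccc2)C1=O`, giving 29.6%
- compound 2, `CCOC(=O)C1=C(Nc2ccccc2)S/C(=C\c2ccc(OC)cc2)C1=O`, giving 17.5%
- compound 3, `CCOC(=O)C1=C(Nc2ccccc2)S/C(=C\c2ccc[nH]2)C1=O`, giving 23.5%

Compound 3 sits in the middle of these three numbers, but its neighbours are close: compound 2 lies a number 6 percentage points higher from compound 2 to compound 3 (within the scatter) and compound 1 lies a number 6.1 percentage points lower from compound 1 to compound 3 (within the scatter), so all three compounds read much the same within the usual scatter. Among the measured compounds shown here, the one step that clearly stands out is a number 12.1 percentage points lower from compound 1 to compound 2 (beyond the scatter), and it concerns the arylidene end of the shared core, not the part that changes here.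

Compound 4, `CCOC(=O)C1=C(Nc2cccc(C(F)(F)F)c2)S/C(=C\c2ccc[nH]2)C1=O`, differs from compound 3 only in that a (trifluoromethyl in place of hydrogen on an aromatic carbon), on the ring attached through the amine. For the measured compounds named here, no measured step touches this ring, so there is nothing direct to lean on. The only analogy is the addition of a small group elsewhere on an aromatic ring, which gave the modest lowering seen in a number 12.1 percentage points lower from compound 1 to compound 2 (beyond the scatter); that is weak guidance for a different position and a different group.

On this basis compound 4 is expected to land near compound 3, with a number 1.5 percentage points lower from compound 3 to compound 4 (within the scatter) as the estimated step, and a widened range to reflect the lack of bearing data: 22%, between 8% and 40%.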

Compound 4, a percentage reported as inhibition, at one concentration (the size of the read-out at that concentration, not a potency): 22.8%
Compound 4: middle estimate off by 0.8 percentage points, on the low side; low and high end bracket the measured number.
By their numbers in this assay, from the lowest: compounds 2, 4, 3 and 1 (each within the scatter of the next, the first and the last beyond it).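

Among the compounds shown here, compound 4 gives the first look at the ring attached through the amine, and in this assay placing trifluoromethyl there, in place of hydrogen on an aromatic carbon, gives a number 0.7 percentage points lower from compound 3 to compound 4 (within the scatter) for this pair. For the compounds shown here, a group of 4 heavy atoms can therefore occupy this place, meta to a large group, without a detectable shift in this one-concentration read-out, whereas the only step beyond the scatter among the earlier compounds, a number 12.1 percentage points lower from compound 1 to compound 2 (beyond the scatter) with methoxy in place of hydrogen, lies on the other aromatic ring. Nothing available on these compounds explains why the number holds steady here.

The compounds shown leave open whether an amine or a carboxylic acid in this same place would move the number beyond the scatter, and whether trifluoromethyl on another carbon of this ring would read the same. Also open, from the compounds shown here alone, is whether this change would read alike with the phenyl of compound 1 or the 4-methoxyphenyl of compound 2 in place of 1H-pyrrol-2-yl, and how the pair compares at other concentrations.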